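Ethoxy to cyclopropylamino on the shared core

The compounds below may be only part of what the source reports. "The series", "measured", "known", "first", "only" and "open" are said of these compounds alone.

Measured in a functional assay on CCRF-CEM cells (Homo sapiens); a lower number here means a stronger inhibitor, a higher number a weaker inhibitor:
Compound 1 (`CCOc1ncnc2c1ncn2C[C@@H]1C[C@H](CO)c2ccccc21`): 24 ug/mL
Compound 2 (`Cn1ncc2c1[C@H](Cn1ccc(=O)[nH]c1=O)C[C@@H]2CO[Si](c1ccccc1)(c1ccccc1)C(C)(C)C`): 3.2 ug/mL

Of these two measurements, compound 1 carries the higher number and so is the weaker inhibitor, and the gap to compound 2 lies beyond the scatter. Compound 2 differs from compound 1 in more than one place, so the pair gives no single-change step to reason from.

The next compound to be read is compound 3 (`OC[C@H]1C[C@@H](Cn2cnc3c(NC4CC4)ncnc32)c2ccccc21`), which keeps the core of compound 1. Cyclopropylamino takes the place of ethoxy on an aromatic carbon of a six-membered aromatic ring with 2 nitrogen, part of a fused or bridged system of two rings (cyclopropylamino in place of ethoxy on an aromatic carbon). Among the measured compounds shown here, no measured step covers this exchange. For the measured compounds named here, the only anchor is compound 1 at 24 ug/mL in this assay and the estimate starts from that value. Estimated for this exchange is a 1.5-fold lower number from compound 1 to compound 3 (0.18 log units; within the scatter) in this assay and so no change beyond the scatter, with any drift expected towards a lower number. The estimated value for compound 3 is 16 ug/mL (expected range 6 ug/mL to 45 ug/mL).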

Compound 3, half-maximal inhibitory concentration: 24 ug/mL
For compound 3 the middle estimate is 1.5-fold (0.18 log units) below the measured one, within the range that was stated.
By their numbers in this assay, from the lowest: compound 2; then compounds 1 and 3 (each within the scatter of the next).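

In this assay, among the compounds shown here, cyclopropylamino in place of ethoxy on an aromatic carbon of the six-membered aromatic ring with 2 nitrogen gives no change at the digits printed from compound 1 to compound 3 (within the scatter), the first single-change step. For this pair, exchanging a group with no ring and no hydrogen-bond donor for one carrying a three-membered non-aromatic ring of carbon only and a hydrogen-bond donor leaves the read-out unmoved, so neither of these differences shows up in the number here. Nothing at hand explains why the two compounds read alike.

This single step does not show whether the position is insensitive to its substituent in general or whether these two groups merely happen to read alike, and a plain amino group, dimethylamino or a longer chain such as butoxy on the same aromatic carbon would test this. On these data alone, the hydroxymethyl group shared by compound 1 and compound 3 also remains untested by any single-change step, and a carboxylic acid or a methyl ether in its place would show whether the number depends on that site.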